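A few compounds are considered here, and "the series" means these few. Any claim that something is new, unique, unknown or untested is made for them only; others in the source may bear on it.

Measured in a functional assay on CCRF-CEM cells (Homo sapiens) for cytotoxicity; on this read-out higher numbers stand for weaker inhibition and lower numbers for stronger inhibition:

Compound 1 `Cc1cn([C@@H]2S[C@H](CO)[C@H]2CO)c(=O)[nH]c1=O`: > 100000 nM, a limit of the assay.
Compound 2 `Nc1ccn([C@@H]2S[C@H](CO)[C@H]2CO)c(=O)n1`: 4300 nM.
Compound 3 `Nc1ncnc2c1ncn2[C@@H]1S[C@H](CO)[C@H]1CO`: > 100000 nM, a limit of the assay.

Within the data shown here, compound 2 gives 4300 nM, the only true number. The rest of the series is described by the limit of > 100000 nM in this assay, at which 2 of the 3 values shown sit.

The next compound to be read is compound 4 `Nc1ccn([C@H]2S[C@@H](CO)[C@@H]2CO)c(=O)n1`. Its relation to compound 2 is the two compounds have the same atoms and bonds and differ only in configuration as drawn: 3 of 3 stereo elements differ (all stereocentres are inverted: mirror images); a stereocentre at a saturated ring carbon is drawn R in compound 2 and S in compound 4; a stereocentre at a saturated ring carbon is drawn S in compound 2 and R in compound 4; a stereocentre at a saturated ring carbon is drawn R in compound 2 and S in compound 4. The two compounds are therefore mirror images, with all stereocentres inverted.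

Among the measured compounds shown here, no measured pair shows what such an inversion does, so the expectation rests on the structural change alone and is loose. Weaker inhibition is expected in this assay, by a clear margin beyond the usual scatter, and a reading that reaches the limit of the assay is quite possible. The expected size is a 7.0-fold higher number from compound 2 to compound 4 (0.84 log units; beyond the scatter). For compound 4 the estimated value is 30000 nM, with an expected range of 4000 nM to 100000 nM.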

Compound 4, half-maximal inhibitory concentration: 45600 nM
For compound 4 the middle estimate is 1.5-fold (0.18 log units) below the measured one; low and high end bracket the measured number.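

In this assay, the series now holds its first readable step: inverting all stereocentres gives an 11-fold higher number from compound 2 to compound 4 (1.03 log units; beyond the scatter), so this read-out distinguishes between the two mirror images. The earlier compounds shown here could not show this, as none of them formed a pair differing in configuration alone. Compound 4 also gives a true number rather than a limit, and the shift can be assigned to configuration and nothing else: the fact that compounds 2 and 4 differ only in the configuration as drawn.

On these data alone, it remains open whether the same inversion acts alike with the bases of compound 1 and compound 3, and whether a fluorine or a carboxylic acid on the core of compound 2 would shift the read-out. The data do not tell what underlies the gap between the mirror images in these cells.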